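The source may report more compounds than this note shows. Statements on the series, on what has been measured and on what is new or still open speak of the compounds shown alone.

Compound 1 `Cc1n[nH]cc1-c1cc2c(s1)C(=O)N[C@]1(CC[C@@](O)(c3ccc(F)cc3)CC1)N2` and compound 2 `Cc1n[nH]cc1-c1cc2c(s1)C(=O)N[C@]1(CC[C@](O)(c3ccc(F)cc3)CC1)N2` share the same atoms and bonds and differ only in the configuration at two ring carbons, so that one is the mirror image of the other. Among the compounds with values here, in an assay for inhibition of Rho-associated protein kinase 1 (Homo sapiens), read by TR-FRET, with stated times of 5 min and 2 h (a lower number here means a stronger inhibitor, a higher number a weaker inhibitor), compound 1 gives 130 nM, while compound 2 gives 820 nM, the higher of the two numbers measured so far; the step of a 6.3-fold higher number from compound 1 to compound 2 (0.80 log units; beyond the scatter) is traced to the fact that compounds 1 and 2 differ only in the configuration as drawn. Compound 3 `Cc1n[nH]cc1-c1cc2c(s1)C(=O)N[C@]1(CC[C@](O)(C3CCCCC3)CC1)N2` keeps the configuration of compound 2 and changes one group: cyclohexyl in place of 4-fluorophenyl on a saturated ring carbon. Within the data shown here, the only measured step concerns configuration alone and gives no guidance on exchanging an aromatic ring for a saturated one, so no step beyond the scatter is expected in this assay and the estimate a 1.0-fold lower number from compound 2 to compound 3 (0.01 log units; within the scatter) is taken as no change, resting on compound 2 alone. Compound 3 is therefore expected to give about 800 nM in this assay. The expected range for compound 3 runs from 250 nM to 2500 nM, wider than the usual scatter to allow for a change of a kind not yet tested here.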

Compound 3, half-maximal inhibitory concentration: 2900 nM
Compound 3: middle estimate off by 3.6-fold (0.56 log units), on the low side; measured number outside the range, above it.
By their numbers in this assay, from the lowest: compound 1; then compound 2; then compound 3.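

Exchanging 4-fluorophenyl for cyclohexyl gives a 3.5-fold higher number from compound 2 to compound 3 (0.55 log units; beyond the scatter) in this assay, so the group on this saturated ring carbon affects the number. Both groups have no hydrogen-bond donors, no hydrogen-bond acceptors and no net charge, so those counts stay the same, but the exchange replaces the aromatic ring with a non-aromatic one and removes the fluorine in a single step, and these two changes cannot be separated here. Within the data shown here, nothing measured so far explains why this exchange raises the number.

Going by these compounds, it remains open whether plain phenyl would give a number closer to compound 2 or to compound 3, which would help separate the role of the fluorine from that of the aromatic ring, and whether a group carrying an amine or a carboxylic acid would be accepted at this position. It is also open whether cyclohexyl would give a similar step in the configuration of compound 1, the lowest number of the three, since the step shown here belongs to the configuration of compound 2 alone.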